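The source may hold more compounds than are shown below. What is called first, only, known or untested is meant among the compounds shown, and "the series" means these compounds.

Values in an ADME assay on microsomes from liver (Homo sapiens) for metabolic stability; on this read-out higher numbers stand for a longer-lived compound and lower numbers for a shorter-lived compound:
- Compound 1 `CC#C[C@@H](Cc1nnn[nH]1)c1ccc(OCc2ccc3sc(F)c(-c4ccccc4C)c3c2)cc1`: 0.0667 h
- Compound 2 `CC#C[C@@H](Cc1nnn[nH]1)c1ccc(OCc2ccc3sc(Cl)c(-c4ccccc4C)c3c2)cc1`: 0.175 h
- Compound 3 `CC#C[C@@H](Cc1nnn[nH]1)c1ccc(OCc2ccc3sc(I)c(-c4ccccc4C)c3c2)cc1`: not yet measured

Of the two measured compounds, compound 2 has the higher number, 0.175 h, and so is the longer-lived of the pair. The next change puts iodo in place of chloro on an aromatic carbon, next to the ring sulfur of the five-membered aromatic ring (iodo in place of chloro on an aromatic carbon).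

Among the measured compounds shown here, only one measured step bears on this change: a 2.6-fold higher number from compound 1 to compound 2 (0.42 log units; beyond the scatter). There, chloro replaced fluoro at the same place. That step was modest, and a single pair cannot establish a trend. A further small rise in this assay is therefore expected, probably not beyond the scatter. The expected step is a 1.4-fold higher number from compound 2 to compound 3 (0.15 log units; within the scatter). The estimate for compound 3 is 0.25 h, with an expected range of 0.11 h to 0.55 h.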

Compound 3, half-life: 0.167 h
Beside the measured number, compound 3's estimate is 1.5-fold (0.18 log units) above it, and the stated range covers the measured number.
By their numbers in this assay, from the lowest: compound 1; then compounds 3 and 2 (each within the scatter of the next).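

In this assay, iodo in place of chloro at this position leaves the two compounds within the scatter of each other (a 1.0-fold lower number from compound 2 to compound 3 (0.02 log units; within the scatter)), so going on to the larger halogen brings no further gain. Compound 1 is now the one that stands apart: iodo in place of fluoro (a 2.5-fold higher number from compound 1 to compound 3 (0.40 log units; beyond the scatter)) gives a step much like that of chloro in place of fluoro (a 2.6-fold higher number from compound 1 to compound 2 (0.42 log units; beyond the scatter)), so among these three compounds, only the steps away from fluoro lie beyond the scatter. Nothing shown here explains this result.

From the compounds shown here alone, all three compounds carry a halogen at this position, so it remains open how a methyl, a nitrile or an amine there would compare. The same holds for a plain hydrogen, which would show how the halogens compare with having no substituent at all.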